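This account rests on a few compounds, and the source may have more. Where it says the series, first, only, none or still open, it means among the compounds named here.

Measured compounds, with their values in a functional assay on SK-BR-3 cells (Homo sapiens) for antiproliferative activity, read by MTT assay, with a stated time of 72 h; a lower number here means a stronger inhibitor, a higher number a weaker inhibitor:

compound 1 `C=C(C)CCOC(=O)C[C@@H]1C(C(=O)OC)=CO[C@@H](O[C@@H]2O[C@H](CO)[C@@H](O)[C@H](O)[C@H]2O)/C1=C/C` — reported only as a limit, > 15000 nM
compound 2 `C/C=C1/[C@H](O[C@@H]2O[C@H](COC(C)=O)[C@@H](OC(C)=O)[C@H](OC(C)=O)[C@H]2OC(C)=O)OC=C(C(=O)OC)[C@H]1CC(=O)OCC` — reported only as a limit, > 15000 nM
compound 3 `C=C(C)CCOC(=O)C[C@@H]1C(C(=O)OC)=CO[C@@H](O[C@@H]2O[C@H](COC(C)=O)[C@@H](OC(C)=O)[C@H](OC(C)=O)[C@H]2OC(C)=O)/C1=C/C` — reported only as a limit, > 15000 nM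

Compound 1 stands nowhere in particular on these numbers: its value in this assay is a limit and not a number, and the other two values shown are limits as well. Among the measured compounds shown here, all three sit at the limit of > 15000 nM in this assay, at which 3 of the 3 values shown sit, so no measured compound separates itself from the others.

For the measured compounds named here, the one step between measured compounds that differ in a single place, a step that the two limits leave unreadable from compound 2 to compound 3, is unreadable because both ends sit at the limit of > 15000 nM in this assay, at which 3 of the 3 values shown sit; it says nothing about size or direction.

Compound 4 `C/C=C1/[C@H](O[C@@H]2O[C@H](CO)[C@@H](O)[C@H](O)[C@H]2O)OC=C(C(=O)OC)[C@H]1CC(=O)OCCCC` differs from compound 1 by ethyl in place of 1-methylethenyl on a saturated chain carbon, two bonds along the chain from an oxygen next to a carbonyl group. Going by the values given here, no measured step bears readably on this change: the step from compound 2 to compound 3 touches the same chain position but leaves nothing to read. Since every value shown is a limit, the expectation for compound 4 is that it also comes back as a limit in this assay, with the expected step that the limit leaves unreadable from compound 1 to compound 4 amounting to nothing beyond the scatter. The estimate for compound 4 is therefore 25000 nM, with a range from 10000 nM to 80000 nM.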

Compound 4, half-maximal inhibitory concentration: > 15000 nM
Compound 4 gave a limit, no number; the forecaster's own chance of this, stated with the estimate: 85%; the middle value does not contradict the limit.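

In this assay compound 4 gives > 15000 nM, a limit and not a number. Compound 1 is also reported only as a limit, so no step can be read between compound 1 and compound 4, and all compounds shown share one limit: the limit of > 15000 nM in this assay, at which 4 of the 4 values shown sit. The compounds shown leave open whether any change to the ester chain or the sugar acetates yields a numerical value in this assay.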